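The source may report more compounds than this note shows. Statements on the series, on what has been measured and on what is new or still open speak of the compounds shown alone.

Measured so far in a functional assay on SW982 cells (Homo sapiens) for inhibition, read by MTT assay, with a stated time of 72 h (a lower number here means a stronger inhibitor, a higher number a weaker inhibitor), and still open:
- compound 1 `COc1ccc(C(=O)/C=C/c2cc(OC)c(OC)cc2OC)cc1` gives 60500 nM
- compound 2 `COc1cc(OC)c(OC)cc1/C=C/C(=O)c1ccccc1` gives > 150000 nM
- compound 3 `COc1cc(OC)c(OC)cc1/C=C/C(=O)c1ccc(-c2c[nH]cn2)cc1` is not yet measured

Compound 2 stands at > 150000 nM as a limit of this assay and not as a number. Compound 3 differs from it by 1H-imidazol-4-yl in place of hydrogen on an aromatic carbon. Going by the values given here, only one measured step bears on this carbon: an at least 2.4-fold higher number from compound 1 to compound 2 (0.39 log units; beyond the scatter), with methoxy replaced by hydrogen. Compound 1 carries methoxy there and reads 60500 nM, so a lower number is expected on adding 1H-imidazol-4-yl. The expected step is an at least 5.0-fold lower number from compound 2 to compound 3 (0.69 log units; beyond the scatter), and it is uncertain because its start is a limit. For compound 3 the expected value is 30000 nM, with an estimated range of 8000 nM to 110000 nM.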

Compound 3, half-maximal inhibitory concentration: > 150000 nM
Compound 3: no number, only a limit; the forecaster's own chance of this, stated with the estimate: 15%; middle value at least 5.0-fold (0.69 log units) away from the limit.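

In this assay, 1H-imidazol-4-yl in place of methoxy on this aromatic carbon gives an at least 2.4-fold higher number from compound 1 to compound 3 (0.39 log units; beyond the scatter), so this group does not match methoxy here. Among the three groups shown at this carbon, only methoxy gives a number rather than a limit. No order between hydrogen and 1H-imidazol-4-yl can be read, as the step from compound 2 to compound 3 joins two limits: the limit of > 150000 nM in this assay, at which 2 of the 3 values shown sit.

On these data alone, whether an amine or a hydroxyl group on this carbon gives a number in this assay stays open. Also open, as far as these compounds go, is whether any group here gives a lower number than methoxy.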